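The source may hold more compounds than are shown below. What is called first, only, known or untested is meant among the compounds shown, and "the series" means these compounds.

Working notes on the series. In a functional assay on HOP-62 cells (Homo sapiens) for inhibition, read by sulforhodamine B assay (on this read-out lower numbers stand for stronger inhibition of growth and higher numbers for weaker inhibition of growth), compound 1 (`COc1ccc(-c2ccc(-c3ccc(-c4nc5cc(C)ccc5[nH]4)cc3)cc2)cc1OC`) gives 2120 nM, compound 2 (`COc1cc(-c2ccc(-c3ccc(-c4nc5cc(C)ccc5[nH]4)cc3)cc2)cc(OC)c1OC`) gives 2370 nM and compound 3 (`Oc1ccc(-c2ccc(-c3ccc(-c4nc5c(O)cccc5[nH]4)cc3)cc2)cc1`) gives 2410 nM so that all three, compound 2 included, stand level within the scatter. Compound 4 (`COc1cc(-c2ccc(-c3ccc(-c4nc5c(O)cccc5[nH]4)cc3)cc2)cc(OC)c1OC`) departs from compound 2 at one place (4-hydroxy-1H-benzimidazol-2-yl in place of 5-methyl-1H-benzimidazol-2-yl on an aromatic carbon), with 4-hydroxy-1H-benzimidazol-2-yl in place of 5-methyl-1H-benzimidazol-2-yl on an aromatic carbon. Going by the values given here, the one measured step (a 1.1-fold higher number from compound 1 to compound 2 (0.05 log units; within the scatter)) is a different change and stays within the scatter. The entering group already occurs in compound 3 at 2410 nM on a different remainder. No shift beyond the scatter is expected, and the estimated step is a 1.0-fold higher number from compound 2 to compound 4 (0.01 log units; within the scatter) in this assay with no direction favoured. Compound 4 is expected at 2400 nM (estimated range 1100 nM to 5000 nM).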

Compound 4, concentration for 50% growth inhibition: 190 nM
Compound 4: middle estimate off by 13-fold (1.10 log units), on the high side; the measured number lies below the stated range.
By their numbers in this assay, from the lowest: compound 4; then compounds 1, 2 and 3 (each within the scatter of the next).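

On the remainder of compound 2, 4-hydroxy-1H-benzimidazol-2-yl in place of 5-methyl-1H-benzimidazol-2-yl gives a 12-fold lower number from compound 2 to compound 4 (1.10 log units; beyond the scatter) in this assay, so this position can move the number well beyond the scatter, which the level earlier compounds did not show. The entering group alone does not secure a low number, since compound 3 carries it at 2410 nM on a different remainder. Nothing on hand accounts for the step.

Open, as far as these compounds go, is whether the hydroxy itself is required or 4-methoxy-1H-benzimidazol-2-yl or 4-amino-1H-benzimidazol-2-yl would hold the low number. Also open, from the compounds shown here alone, is which features of the remainder of compound 4 the low number depends on.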